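Swapping the Amide Cap of a Chromone Series

This account rests on a few compounds, and the source may have more. Where it says the series, first, only, none or still open, it means among the compounds named here.

Compound 1 `O=C(COc1ccc2c(=O)ccoc2c1)Nc1cccc(NC(=O)c2ccc(Br)cc2)c1`: 49 nM
Compound 2 `CC(C)(C)c1cc(C(=O)Nc2cccc(NC(=O)COc3ccc4c(=O)ccoc4c3)c2)no1`: 5 nM
Compound 3 `Cc1nc(C(=O)Nc2cccc(NC(=O)COc3ccc4c(=O)ccoc4c3)c2)cs1`: 33 nM

Three compounds share one core and differ only in the group on the outer carbonyl carbon, measured in an assay on isolated protein for inhibition of Rho-associated protein kinase 2 (Homo sapiens), read by scintillation counting, radiometric assay and 33P incorporation, with a stated time of 40 min, in the presence of a further agent that is not named here; on this read-out lower numbers stand for stronger inhibition and higher numbers for weaker inhibition. Compound 3 stands second highest of the three numbers: the step of a 1.5-fold lower number from compound 1 to compound 3 (0.17 log units; within the scatter) shows that these two are not separable here, while the step of a 6.6-fold higher number from compound 2 to compound 3 (0.82 log units; beyond the scatter) is a real difference. The step of a 9.8-fold lower number from compound 1 to compound 2 (0.99 log units; beyond the scatter) shows the same thing from the other side.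

Compound 4 `Nc1cccc(C(=O)Nc2cccc(NC(=O)COc3ccc4c(=O)ccoc4c3)c2)c1` is the next variation: 3-aminophenyl in place of 2-methyl-1,3-thiazol-4-yl on a carbonyl carbon. All three earlier steps bear on this change, since each also replaces the group on that carbonyl carbon. Two of them moved the numbers only modestly, and one, between compound 1 and compound 3, not beyond the scatter. Going from a five-membered ring to a six-membered carbon ring, as from compound 3 to compound 1, produced no clear shift, so for compound 4 a step of a 1.1-fold lower number from compound 3 to compound 4 (0.04 log units; within the scatter) is expected, with no direction beyond the scatter. The estimate for compound 4 in this assay is 30 nM, within 8 nM to 120 nM.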

Compound 4, half-maximal inhibitory concentration: 58 nM
Beside the measured number, compound 4's estimate is 1.9-fold (0.29 log units) below it; measured number inside the range.
By their numbers in this assay, from the lowest: compound 2; then compounds 3, 1 and 4 (each within the scatter of the next).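

In this assay, 3-aminophenyl on the carbonyl carbon cannot be told apart from the two groups nearest to it in number: a 1.8-fold higher number from compound 3 to compound 4 (0.24 log units; within the scatter) and a 1.2-fold higher number from compound 1 to compound 4 (0.07 log units; within the scatter) both stay within the scatter, so 4-bromophenyl, 2-methyl-1,3-thiazol-4-yl and 3-aminophenyl read alike here. Going by these compounds alone, the one large step among the new ones is a 12-fold higher number from compound 2 to compound 4 (1.06 log units; beyond the scatter) and it leaves compound 2, with its 5-(tert-butyl)-1,2-oxazol-3-yl group, as the only one of the four set clearly apart from all the others. No measurement shown accounts for what sets that group apart.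

The compounds shown leave open whether the tert-butyl group or the 1,2-oxazole ring carries the difference, as the two appear only together. A 5-methyl-1,2-oxazol-3-yl group and a 4-(tert-butyl)phenyl group on the same carbonyl carbon would separate the two.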